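The source may hold more compounds than are shown below. What is called first, only, known or untested is meant among the compounds shown, and "the series" means these compounds.

Compound 1, `CCOC(=O)C1=C(C)NC(=O)NC1c1ccc(SC)cc1`, gave 10.2 ug/mL.
Compound 2, `CCCc1ccc(C2NC(=S)NC(C)=C2C(=O)OCC)cc1`, gave 50.4 ug/mL.
Compound 3, `CCOC(=O)C1=C(C)NC(=S)NC1c1ccc(SC)cc1`, gave 17.2 ug/mL.

All three were measured in a functional assay on HT-29 cells (Homo sapiens) for inhibition, read by sulforhodamine B assay, with a stated time of 48 h; on this read-out lower numbers stand for stronger inhibition of growth and higher numbers for weaker inhibition of growth. Compound 1 and compound 3 lie within the scatter of each other, while compound 2 stands beyond both of them with the higher number. Compound 2 and compound 3 share a core and differ only by propyl in place of methylsulfanyl on an aromatic carbon; that change produced a 2.9-fold higher number from compound 3 to compound 2 (0.47 log units; beyond the scatter). The unmeasured compound 4, `CCCc1ccc(C2NC(=O)NC(C)=C2C(=O)OCC)cc1`, stands to compound 1 exactly as compound 2 stands to compound 3, since the difference is propyl in place of methylsulfanyl on an aromatic carbon, the same change at the same place. The difference between the core of compound 1 and the core of compound 3 is not broken down here. For compound 4 in this assay a step of about a 2.9-fold higher number from compound 1 to compound 4 (0.47 log units; beyond the scatter) is expected, because the identical change gave a 2.9-fold higher number from compound 3 to compound 2 (0.47 log units; beyond the scatter) on the other core. Compound 4 is therefore estimated at 30 ug/mL, most likely between 15 ug/mL and 60 ug/mL.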

Compound 4, concentration for 50% growth inhibition: 17.5 ug/mL
Beside the measured number, compound 4's estimate is 1.7-fold (0.23 log units) above it, and the stated range covers the measured number.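

On the core of compound 1, propyl in place of methylsulfanyl gave a step that stays within the scatter in this assay (a 1.7-fold higher number from compound 1 to compound 4 (0.23 log units; within the scatter)). Set beside the step on the other core, it does not differ from it by more than two such steps can scatter: the same change on two cores in this assay, a 2.9-fold higher number (0.47 log units; beyond the scatter) from compound 3 to compound 2 and a 1.7-fold higher number (0.23 log units; within the scatter) from compound 1 to compound 4, 1.7-fold (0.23 log units) apart, within the scatter of two such steps. The compounds therefore give no sign that the change reads differently on the two cores, yet with a single pair on each core this does not show that its size is the same on both, nor that it would hold on any further core.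

The compounds shown leave open how other groups on this aromatic carbon would read, such as a longer chain like butyl, an amine or a carboxylic acid, as only methylsulfanyl and propyl stand there. They also leave open whether the two cores would stay as close to each other with a methoxy group in that place.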